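Trifluoromethyl to acetyl: what to expect for compound 3

The compounds below may be only part of what the source reports. "The series", "measured", "known", "first", "only" and "open" are said of these compounds alone.

Compound 1, `CC(C)c1ccccc1NC(=O)N[C@H](C)c1ccccc1`, gives 17% in an ADME assay on the whole organism with Oryza sativa as the target, tested at 10 uM; on this read-out higher numbers stand for a weaker effect at the one concentration tested and lower numbers for a stronger effect.
Compound 2, `C[C@@H](NC(=O)Nc1ccccc1C(F)(F)F)c1ccccc1`, gives 54% in this assay.

Of the two numbers measured, compound 2 stands highest, with compound 1 as its nearest neighbour at 17%. Going by the values given here, the single measured step, a number 37 percentage points higher from compound 1 to compound 2 (beyond the scatter), shows that a change of the group on this aromatic carbon can move the read-out by a large amount. Compound 3, `CC(=O)c1ccccc1NC(=O)N[C@H](C)c1ccccc1`, is not yet measured. It differs from compound 2 by acetyl in place of trifluoromethyl on an aromatic carbon. Among the compounds with values here, no measured step has acetyl entering or leaving, so the one step that bears on the question does so only by showing how much this position can matter, not in which direction acetyl will pull. Given that trifluoromethyl and isopropyl at the same place gave numbers far apart, the expected value for compound 3 is set between them and is uncertain: the expected step is a number 14 percentage points lower from compound 2 to compound 3 (beyond the scatter), and compound 3 is estimated at 40%, within a range from 15% to 65%.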

Compound 3, a percentage reported as activity, at one concentration (the size of the read-out at that concentration, not a potency): 89%
Estimate against measurement, compound 3: 49 percentage points below, and the stated range ends below it.
By their numbers in this assay, from the lowest: compound 1; then compound 2; then compound 3.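

The change to acetyl gives a number 35 percentage points higher from compound 2 to compound 3 (beyond the scatter) in this assay, and the wider comparison gives a number 72 percentage points higher from compound 1 to compound 3 (beyond the scatter), so compound 3 shows the weakest effect of the three at the one concentration tested. The earlier step showed only that this aromatic carbon, ortho to a large group, could move the read-out; these steps show that the span at this place is wider than isopropyl and trifluoromethyl alone suggested, and that acetyl, not trifluoromethyl, stands at its weak end. Acetyl brings one hydrogen-bond acceptor and a double bond outside aromatic rings, where trifluoromethyl has neither, but no measurement here ties the higher number to either feature or to any other cause.

The compounds shown leave open whether the carbonyl of acetyl is what matters, which a comparison with a closely related group such as a methyl ester or a nitrile could begin to test. They also leave open how an amine or a carboxylic acid on this same carbon would read, and whether the order of these three groups would hold on a different core.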